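The compounds below may be only part of what the source reports. "The series", "measured", "known", "first", "only" and "open" are said of these compounds alone.

In a functional assay on PC-12 cells (Rattus norvegicus) for cytotoxicity, read by MTT assay, with stated times of 2 h and 24 h, tested at 1 uM (on this read-out higher numbers stand for a stronger effect at the one concentration tested and lower numbers for a weaker effect), compound 2 `Oc1cc(C(F)(F)F)ccc1-c1nc(-c2ccccc2O)n(-c2cccc(F)c2)n1` gives 67.2%. Compound 1 `N#Cc1ccc(-n2nc(-c3ccc(C(F)(F)F)cc3O)nc2-c2ccccc2O)cc1` gives 66.6% in this assay, and the two numbers lie within the scatter of each other. Going by the values given here, the single measured step, a number 0.6 percentage points higher from compound 1 to compound 2 (within the scatter), swaps the group on the aromatic nitrogen without moving the read-out. Compound 3 `Oc1cc(C(F)(F)F)ccc1-c1nc(-c2ccccc2O)n(-c2cccc(C(F)(F)F)c2)n1` differs from compound 2 by trifluoromethyl in place of fluoro on an aromatic carbon, a further swap on that same ring. Among the compounds with values here, since the only comparable step stayed within the scatter, the expected step of a number 0.2 percentage points lower from compound 2 to compound 3 (within the scatter) is no more than the scatter. Compound 3 is therefore estimated at 67% in this assay, with a range from 54% to 80%.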

Compound 3, a percentage reported as activity, at one concentration (the size of the read-out at that concentration, not a potency): 71.5%
Estimate against measurement, compound 3: 4.5 percentage points below; the measured number falls inside the stated range.
By their numbers in this assay, from the lowest: compounds 1, 2 and 3 (each within the scatter of the next).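

In this assay, trifluoromethyl in place of fluoro on an aromatic carbon, meta to a large group, gives a number 4.3 percentage points higher from compound 2 to compound 3 (within the scatter), so 4 heavy atoms are accommodated there as well as 1. Exchanging the whole group on the aromatic nitrogen, 3-(trifluoromethyl)phenyl in place of 4-cyanophenyl, gives a number 4.9 percentage points higher from compound 1 to compound 3 (within the scatter), so all three groups on that nitrogen read alike. No available evidence bears on this flat result. Open, on these data alone, is whether an amine or a carboxylic acid on that ring would move the read-out beyond the scatter.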